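This account rests on a few compounds, and the source may have more. Where it says the series, first, only, none or still open, it means among the compounds named here.

In a functional assay on A549 cells (Homo sapiens) for cytotoxicity, read by MTT assay, with a stated time of 48 h (on this read-out higher numbers stand for weaker inhibition and lower numbers for stronger inhibition), compound 1 `N#Cc1ccc(Cn2cc(COc3ccc4c(=O)ccoc4c3)nn2)cc1` gives only a limit, > 100000 nM. Compound 2 `O=c1ccoc2cc(OCc3cn(Cc4ccccc4Br)nn3)ccc12` likewise gives only a limit in this assay, > 100000 nM. The step that the two limits leave unreadable from compound 1 to compound 2 is thus not readable in size, and both values sit at the limit of > 100000 nM in this assay, at which 2 of the 2 values shown sit. Compound 3 `O=c1ccoc2cc(OCc3cn(Cc4cccc(Cl)c4)nn3)ccc12` differs from compound 2 by 3-chlorophenyl in place of 2-bromophenyl on a saturated chain carbon bound to an aromatic nitrogen. No readable measured step bears on this change, so no shift beyond the scatter is expected, and compound 3 is expected to remain at the same limit, with a step that the limit leaves unreadable from compound 2 to compound 3. The estimate for compound 3 is 150000 nM, within 50000 nM to 500000 nM.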

Compound 3, half-maximal inhibitory concentration: 13700 nM
Estimate against measurement, compound 3: 11-fold (1.04 log units) above; measured number below the stated range.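

In this assay compound 3 gives the only number that can be read as a value, so the group on the saturated chain carbon bound to an aromatic nitrogen is shown to move the read-out, with an at least 7.2-fold lower number from compound 2 to compound 3 (0.86 log units; beyond the scatter) and an at least 7.2-fold lower number from compound 1 to compound 3 (0.86 log units; beyond the scatter). The earlier pair could not show this, and the other compounds remain at a limit: the limit of > 100000 nM in this assay, at which 2 of the 3 values shown sit.

Since 2-bromophenyl and 3-chlorophenyl differ in both the halogen and its place on the ring, the data do not separate these two changes. As far as these compounds go, how an amine or a carboxylic acid on this phenyl ring, or a longer chain at this carbon, would read remains open.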